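From compound 3 to compound 4: an ethoxy link

A few compounds are considered here, and "the series" means these few. Any claim that something is new, unique, unknown or untested is made for them only; others in the source may bear on it.

Measured in a functional assay on HT-29 cells (Homo sapiens) for inhibition, read by sulforhodamine B assay, with a stated time of 72 h (on this read-out higher numbers stand for weaker inhibition and lower numbers for stronger inhibition), are these compounds:
compound 1 `COc1cc2c(Nc3ccc(F)c(Cl)c3)ncnc2cc1OCCCn1ccnc1[N+](=O)[O-]` with 2060 nM
compound 2 `COc1cc2c(Nc3ccc(F)c(Cl)c3)ncnc2cc1OCCCCCCn1ccnc1[N+](=O)[O-]` with 1840 nM
compound 3 `C#Cc1cccc(Nc2ncnc3cc(OCCCCn4ccnc4[N+](=O)[O-])c(OC)cc23)c1` with 590 nM

Compound 3 gives 590 nM and stands lowest of the three, beyond the scatter from both others. Compound 4 `C#Cc1cccc(Nc2ncnc3cc(OCCOCCn4ccnc4[N+](=O)[O-])c(OC)cc23)c1` carries 2-(2-nitro-1H-imidazol-1-yl)ethoxy in place of 2-(2-nitro-1H-imidazol-1-yl)ethyl on a saturated chain carbon, two bonds along the chain from an oxygen on an aromatic ring. Among the measured compounds shown here, one measured step bears on this chain, a 1.1-fold lower number from compound 1 to compound 2 (0.05 log units; within the scatter) and it stayed within the scatter. For the measured compounds named here, no measured step places an oxygen in the chain. In this assay no change beyond the scatter is therefore expected, and the estimated step is a 1.2-fold higher number from compound 3 to compound 4 (0.07 log units; within the scatter) with little weight on its direction. Compound 4 is estimated at 700 nM with 300 nM to 1600 nM as the expected range.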

Compound 4, half-maximal inhibitory concentration: 6040 nM
Compound 4: middle estimate off by 8.6-fold (0.94 log units), on the low side, outside the stated range (above it).
By their numbers in this assay, from the lowest: compound 3; then compounds 2 and 1 (each within the scatter of the next); then compound 4.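

In this assay, 2-(2-nitro-1H-imidazol-1-yl)ethoxy in place of 2-(2-nitro-1H-imidazol-1-yl)ethyl gave a 10-fold higher number from compound 3 to compound 4 (1.01 log units; beyond the scatter), so this chain does not tolerate every change. Among the compounds shown here, the only earlier step on the chain, a 1.1-fold lower number from compound 1 to compound 2 (0.05 log units; within the scatter), changed its length by carbons alone and stayed within the scatter, so it gave no sign that a change here could matter this much. Nothing measured here accounts for the step. As far as these compounds go, it remains open whether the oxygen or the added chain length drives the step, and whether an all-carbon chain of the same length as in compound 4, or an amine in place of the oxygen, would behave alike.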